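Notes on the step to compound 3

The source may hold more compounds than are shown below. What is called first, only, known or untested is meant among the compounds shown, and "the series" means these compounds.

Measured so far:
compound 1 `COC(=O)N1N=C(c2cc(OC)c(OC)c(OC)c2)CC1c1cc(OC)c(OC)c(OC)c1` gives 7850 nM
compound 2 `COC(=O)N1N=C(c2ccc(O)cc2)CC1c1cc(OC)c(OC)c(OC)c1` gives 6770 nM

In a functional assay on HT-29 cells (Homo sapiens) for antiproliferative activity, read by MTT assay, with a stated time of 48 h (on this read-out higher numbers stand for weaker inhibition of growth and lower numbers for stronger inhibition of growth), compound 2 at 6770 nM stands level with compound 1 at 7850 nM within the usual scatter. Compound 3 `COC(=O)N1N=C(c2ccc(OC)c(OC)c2)CC1c1cc(OC)c(OC)c(OC)c1` carries 3,4-dimethoxyphenyl in place of 4-hydroxyphenyl on a carbon with a double bond to nitrogen and has not yet been measured. For the measured compounds named here, no step between measured compounds that differ in one place is available, so the expectation rests on two values alone. Compound 1 at 7850 nM and compound 2 at 6770 nM lie within the scatter of each other, so no step beyond the scatter is expected in this assay and no direction is favoured. The expected 1.1-fold lower number from compound 2 to compound 3 (0.05 log units; within the scatter) stays small on this estimate. For compound 3 the estimated value is 6000 nM with an expected range from 2000 nM to 15000 nM as the upper end.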

Compound 3, concentration for 50% growth inhibition: 9200 nM
Estimate against measurement, compound 3: 1.5-fold (0.19 log units) below; the range from low to high includes it.
By their numbers in this assay, from the lowest: compounds 2, 1 and 3 (each within the scatter of the next).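

In this assay, 3,4-dimethoxyphenyl in place of 4-hydroxyphenyl on a carbon with a double bond to nitrogen gives a 1.4-fold higher number from compound 2 to compound 3 (0.13 log units; within the scatter), so at this position the series keeps its level with or without the hydrogen-bond donor of 4-hydroxyphenyl. Hydrogen in place of methoxy on an aromatic carbon gives a 1.2-fold higher number from compound 1 to compound 3 (0.07 log units; within the scatter), so this single edit to the aryl group of compound 1 also leaves the read-out within the scatter, and the three aryl groups seen here cannot be separated. Nothing available explains this flat response.

The compounds shown leave open whether an amine or a carboxylic acid on this aromatic ring would move the number beyond the scatter. They also leave open whether an ethoxycarbonyl group or an amide in place of methoxycarbonyl would do so.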